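From compound 3 to compound 4: tolerance in cells

The source may report more compounds than this note shows. Statements on the series, on what has been measured and on what is new or still open speak of the compounds shown alone.

Values so far in an ADME assay on MT4 cells (Homo sapiens) for cytotoxicity, read by MTT assay (a higher number here means that more compound is tolerated, a lower number that less compound is tolerated), are these:
- compound 1 `O=C1c2ccccc2C(=O)N1CCOC(=S)N(C(=O)c1ccccc1[N+](=O)[O-])c1ccc(Cl)cc1` (21000 nM)
- compound 2 `O=C1c2ccccc2C(=O)N1CCOC(=S)N(C(=O)c1ccc(Cl)c(Cl)c1)c1ccccc1` (52000 nM)
- compound 3 `O=C1c2ccccc2C(=O)N1CCOC(=S)N(C(=O)c1ccc(F)c(F)c1)c1ccc(Cl)cc1` (52000 nM)

Compound 3 stands level with compound 2, and the two share the highest number of the three, while compound 1 sits lower. The next compound to be tested is compound 4 `COc1cccc(OC)c1C(=O)N(C(=S)OCCN1C(=O)c2ccccc2C1=O)c1ccc(Cl)cc1`, which has 2,6-dimethoxyphenyl in place of 3,4-difluorophenyl on a carbonyl carbon.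

Going by the values given here, only one measured step changes a group at this same place (a 2.5-fold higher number from compound 1 to compound 3 (0.39 log units; beyond the scatter)), with 3,4-difluorophenyl in place of 2-nitrophenyl. That step is modest, so a change here has so far moved the number only a little. Among the compounds with values here, no measured compound carries 2,6-dimethoxyphenyl, so the direction is uncertain, and a small fall is expected at most. The expected step is (a 1.3-fold lower number from compound 3 to compound 4 (0.11 log units; within the scatter)), which is no clear move beyond the scatter. For compound 4 the estimated value is 40000 nM (expected range 17000 nM to 90000 nM).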

Compound 4, half-maximal cytotoxic concentration: 69000 nM
For compound 4 the middle estimate is 1.7-fold (0.24 log units) below the measured one; low and high end bracket the measured number.
By their numbers in this assay, from the lowest: compound 1; then compounds 2, 3 and 4 (each within the scatter of the next).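

In this assay the swap on the carbonyl carbon gives a 1.3-fold higher number from compound 3 to compound 4 (0.12 log units; within the scatter), so 2,6-dimethoxyphenyl and 3,4-difluorophenyl cannot be told apart here, even though the entering group counts two hydrogen-bond acceptors and the leaving group none. Against 2-nitrophenyl the new group gives a 3.3-fold higher number from compound 1 to compound 4 (0.52 log units; beyond the scatter), the same direction as a 2.5-fold higher number from compound 1 to compound 3 (0.39 log units; beyond the scatter), so two different groups at this place now both stand clear of compound 1. No measurement available here explains why the number responds this way.

From the compounds shown here alone, whether the lower number belongs to 2-nitrophenyl alone stays open, as does whether a phenyl ring carrying an amine or a carboxylic acid would stay with compound 3 and compound 4 or fall toward compound 1. Only one arrangement of the two methoxy groups appears, so the effect of moving them is also unknown.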